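Aryl tail variation on the shared core

The source may report more compounds than this note shows. Statements on the series, on what has been measured and on what is new or still open speak of the compounds shown alone.

Measured so far:
compound 1 `FC1(Cc2ccccc2C(F)(F)F)CCN(CCCc2c[nH]c3ccc(-n4cnnc4)cc23)CC1`, 14 nM
compound 2 `Fc1ccccc1CCC1(F)CCN(CCCc2c[nH]c3ccc(-n4cnnc4)cc23)CC1`, 16 nM
compound 3 `Fc1ccc(CCC2(F)CCN(CCCc3c[nH]c4ccc(-n5cnnc5)cc34)CC2)cc1`, 25 nM

In an assay on CHO cells for displacement of a labelled ligand from 5-hydroxytryptamine receptor 1B (Homo sapiens) (a higher number here means a weaker inhibitor, a lower number a stronger inhibitor), compound 3 holds the highest of the three numbers, though its gaps to the others are both within the scatter: a 1.6-fold higher number from compound 2 to compound 3 (0.19 log units; within the scatter) and a 1.8-fold higher number from compound 1 to compound 3 (0.25 log units; within the scatter). Compound 4 `CC(CC1(F)CCN(CCCc2c[nH]c3ccc(-n4cnnc4)cc23)CC1)c1ccccc1` differs from compound 3 by 1-phenylethyl in place of 4-fluorobenzyl on a saturated chain carbon bound to a saturated ring carbon. Among the compounds with values here, no measured pair changes the tail in quite this way; the nearest are the swaps among compounds 1, 2 and 3, of which a 1.1-fold higher number from compound 1 to compound 2 (0.06 log units; within the scatter) is the closest analogue, and all three fell within the scatter. The aryl tail therefore appears tolerant of substitution changes here, so no step beyond the scatter is expected: a 1.1-fold lower number from compound 3 to compound 4 (0.06 log units; within the scatter). Compound 4 is estimated at 22 nM, between 8 nM and 60 nM.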

Compound 4, half-maximal inhibitory concentration: 28 nM
The estimate for compound 4 lay 1.3-fold (0.10 log units) below the measured number, and the stated range covers the measured number.
By their numbers in this assay, from the lowest: compounds 1, 2, 3 and 4 (each within the scatter of the next).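

Replacing 4-fluorobenzyl with 1-phenylethyl on a saturated chain carbon bound to a saturated ring carbon shows that this position also accepts a tail with no fluorine (a 1.1-fold higher number from compound 3 to compound 4 (0.05 log units; within the scatter)). The same tail remains within the scatter of the other two tails (a 1.8-fold higher number from compound 2 to compound 4 (0.24 log units; within the scatter); a 2.0-fold higher number from compound 1 to compound 4 (0.30 log units; within the scatter)). No supporting data bear on why this change is tolerated.

All four tails carry a six-membered aromatic ring of carbon only. As far as these compounds go, how an amine, a carboxylic acid or a longer chain at this position would behave remains open.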